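Pyridyl change at the five-membered ring, compound 3 to compound 4

The source may hold more compounds than are shown below. What is called first, only, known or untested is meant among the compounds shown, and "the series" means these compounds.

Compound 1 `Cc1cccc(-c2noc([C@H](C)NC(=O)c3cc(C4CC4)n(C)n3)n2)c1` reaches only the limit of > 30000 nM in an assay on T-REx-293 cells for inhibition of potassium channel subfamily T member 1 (Homo sapiens), read by patch clamp; on this read-out higher numbers stand for weaker inhibition and lower numbers for stronger inhibition. Compound 2 `Cc1cccc(-c2noc([C@H](C)NC(=O)c3cc(C(F)(F)F)nn3C)n2)n1` likewise sits at the limit of > 30000 nM. Going by the values given here, compound 3 `Cc1cncc(-c2noc([C@H](C)NC(=O)c3cc(C(F)(F)F)nn3C)n2)c1` gives 1370 nM in this assay, the only number among the three values shown. Among the compounds with values here, the step of an at least 21-fold lower number from compound 2 to compound 3 (1.34 log units; beyond the scatter) is the one measured change that yields a number, moving the series away from the limit of > 30000 nM in this assay, at which 2 of the 3 values shown sit. Compound 4 `C[C@H](NC(=O)c1cc(C(F)(F)F)nn1C)c1nc(-c2ccncc2)no1` carries pyridin-4-yl in place of 5-methylpyridin-3-yl on an aromatic carbon. Within the data shown here, no measured step covers removing the methyl or shifting the ring nitrogen to this position, so the direction is open. The change is expected to stay close to the scatter, with a 2.2-fold higher number from compound 3 to compound 4 (0.34 log units; beyond the scatter) as the estimated step. Compound 4 is therefore expected at 3000 nM, within 700 nM to 15000 nM.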

Compound 4, half-maximal inhibitory concentration: 5250 nM
Compound 4: middle estimate off by 1.8-fold (0.24 log units), on the low side; measured number inside the range.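

In this assay, pyridin-4-yl costs some inhibition against 5-methylpyridin-3-yl, with a 3.8-fold higher number from compound 3 to compound 4 (0.58 log units; beyond the scatter), yet it still gives a number, with an at least 5.7-fold lower number from compound 2 to compound 4 (0.75 log units; beyond the scatter). Compound 2 stays a limit and not a number, so that second step is only a bound: the limit of > 30000 nM in this assay, at which 2 of the 4 values shown sit. Two pyridyl groups, in compound 3 and compound 4, now give numbers at this position, and the 6-methylpyridin-2-yl group of compound 2 goes against any wider pyridyl pattern.

Going by these compounds alone, no pair separates the loss of the methyl from the shift of the ring nitrogen. From the compounds shown here alone, an amine or a carboxylic acid on the pyridine, or a longer chain in place of the methyl, remains open.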